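One Stereocentre Redrawn: Compound 3 to Compound 4

A few compounds are considered here, and "the series" means these few. Any claim that something is new, unique, unknown or untested is made for them only; others in the source may bear on it.

Measured so far, all in an ADME assay on the whole organism with Oryza sativa as the target, tested at 1 uM; a higher number here means a weaker effect of the compound at the concentration tested, a lower number a stronger effect:
compound 1, `CCc1cccc(NC(=O)N[C@@H](C)c2ccccc2)c1`, gives 94%
compound 2, `CCOC(=O)c1cccc(NC(=O)N[C@@H](C)c2ccccc2)c1`, gives 99%
compound 3, `COc1cccc(NC(=O)N[C@H](C)c2ccccc2)c1`, gives 92%

Compound 3 holds the lowest of the three numbers, yet neither neighbour stands apart from it: the nearest is compound 1, the furthest compound 2, and both gaps fall within the usual scatter of this assay, so the three read as one cluster of weak effects.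

Compound 4, `COc1cccc(NC(=O)N[C@@H](C)c2ccccc2)c1`, has not been measured. How it differs from compound 3: the two compounds have the same atoms and bonds and differ only in configuration as drawn: 1 of 1 stereo elements differ; a stereocentre at a saturated chain carbon is drawn R in compound 3 and S in compound 4

Within the data shown here, the single measured step, a number 5 percentage points higher from compound 1 to compound 2 (within the scatter), swaps a group on the aromatic ring and was itself within the scatter; it says nothing about a change of configuration. Among the measured compounds shown here, no measured pair differs only in configuration, so no step bears directly on this change.

Compound 4 is therefore expected to stay near compound 3, with a number 2 percentage points higher from compound 3 to compound 4 (within the scatter) no larger than the scatter. The estimate for compound 4 is 94%, expected to lie between 84% and 100%.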

Compound 4, a percentage reported as activity, at one concentration (the size of the read-out at that concentration, not a potency): 99%
Beside the measured number, compound 4's estimate is 5 percentage points below it, within the range that was stated.
By their numbers in this assay, from the lowest: compounds 3, 1, 2 and 4 (each within the scatter of the next).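

Among these compounds, compounds 3 and 4 are the first measured pair that isolates the stereocentre at the saturated chain carbon, and they give a number 7 percentage points higher from compound 3 to compound 4 (within the scatter) in this assay, a step that reflects configuration alone: the fact that compounds 3 and 4 differ only in the configuration as drawn. Redrawing this centre from R to S therefore does not separate the two compounds beyond the scatter. With the centre drawn S throughout, the group on the aromatic carbon does not separate the compounds either, giving no change at the digits printed from compound 2 to compound 4 (within the scatter) for methoxy in place of ethoxycarbonyl and a number 5 percentage points higher from compound 1 to compound 4 (within the scatter) for methoxy in place of ethyl.

From the compounds shown here alone, all four compounds lie within the scatter of one another, so it stays open whether configuration would count in a compound with a clearly stronger effect. Going by these compounds, whether an amine or a carboxylic acid on the aromatic carbon would give such a compound also remains unknown.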